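The source may report more compounds than this note shows. Statements on the series, on what has been measured and on what is new or still open speak of the compounds shown alone.

Compounds measured in an assay on isolated protein for inhibition of serine/threonine-protein kinase TNNI3K (Homo sapiens); a higher number here means a weaker inhibitor, a lower number a stronger inhibitor:
compound 1 `CCNc1cc(Oc2ccc(NC(=O)Nc3cccc(C(F)(F)F)c3)cc2)ncn1`, giving 25 nM
compound 2 `O=C(Nc1ccc(Oc2ccncn2)cc1)Nc1cccc(C(F)(F)F)c1`, giving 160 nM

Compound 2 has the highest number of the two, with compound 1 the nearest neighbour at a lower number, and that one step is all that is known here: a 6.4-fold higher number from compound 1 to compound 2 (0.81 log units; beyond the scatter). Compound 3 `O=C(Nc1ccc(Oc2cc(O)ncn2)cc1)Nc1cccc(C(F)(F)F)c1` returns to the same aromatic carbon with a different group: hydroxy in place of hydrogen on an aromatic carbon. Since removing ethylamino from that carbon cost potency, putting hydroxy there may win a little of it back, and the step from compound 2 to compound 3 is expected to be a 2.0-fold lower number from compound 2 to compound 3 (0.30 log units; within the scatter). Compound 3 is therefore estimated at 80 nM, between 30 nM and 250 nM.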

Compound 3, half-maximal inhibitory concentration: 3200 nM
Beside the measured number, compound 3's estimate is 40-fold (1.60 log units) below it, outside the stated range (above it).
By their numbers in this assay, from the lowest: compound 1; then compound 2; then compound 3.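

In this assay, putting a group back on this aromatic carbon does not by itself restore potency: hydroxy is clearly worse than plain hydrogen (a 20-fold higher number from compound 2 to compound 3 (1.30 log units; beyond the scatter)). The two groups on this carbon therefore push potency in opposite directions, and the gap between them is large (a 130-fold higher number from compound 1 to compound 3 (2.11 log units; beyond the scatter)). No information is available on why hydroxy and ethylamino differ so strongly. As far as these compounds go, it remains open whether the nitrogen of ethylamino matters most, or whether methoxy, a plain amine or a longer chain such as propylamino would match it.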